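The source may hold more compounds than are shown below. What is called first, only, known or untested is meant among the compounds shown, and "the series" means these compounds.

Three compounds have been measured in an assay on isolated protein (Asteroidea) for inhibition of G2/mitotic-specific cyclin-B (Asterina pectinifera), read by scintillation counting and 33P incorporation, with a stated time of 30 min; a lower number here means a stronger inhibitor, a higher number a weaker inhibitor:

Compound 1 `CCC[C@@H](O)Nc1nc(Nc2ccc(-c3ncccn3)cc2)c2ncn(C(C)C)c2n1` gives 180 nM.
Compound 2 `CCC[C@@H](O)Nc1nc(Nc2ccc(-c3cncnc3)cc2)c2ncn(C(C)C)c2n1` gives 40 nM.
Compound 3 `CCC[C@@H](O)Nc1nc(Nc2cccc(-c3ncccn3)c2)c2ncn(C(C)C)c2n1` gives 300 nM.

Compound 1 and compound 2 share a core and differ in a single group: pyrimidin-5-yl in place of pyrimidin-2-yl on an aromatic carbon. That change made the step of a 4.5-fold lower number from compound 1 to compound 2 (0.65 log units; beyond the scatter). Compound 3 is built on a core that is not the same as the core of compound 1; how the two cores differ is not broken down here, and the two values alone show that compound 3 and compound 1 lie within the usual scatter of each other.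

Compound 4 `CCC[C@@H](O)Nc1nc(Nc2cccc(-c3cncnc3)c2)c2ncn(C(C)C)c2n1` has not yet been measured. It relates to compound 3 as compound 2 relates to compound 1: pyrimidin-5-yl in place of pyrimidin-2-yl on an aromatic carbon. The group that leaves and the group that enters are the same as before, but the surroundings are not: in compound 1 the group sits para to a large group, in compound 3 it sits meta to a large group. Within the data shown here, this is therefore the same kind of change, not the same change, and the one step it made so far is the only guide.

The step from compound 3 to compound 4 is expected to be a 3.0-fold lower number from compound 3 to compound 4 (0.48 log units; beyond the scatter) because a 4.5-fold lower number from compound 1 to compound 2 (0.65 log units; beyond the scatter) is what the same kind of change gave at a different place, which leaves room for a smaller or larger step here. The estimate for compound 4 in this assay is 100 nM, with an expected range from 40 nM to 250 nM.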

Compound 4, half-maximal inhibitory concentration: 130 nM
For compound 4 the middle estimate is 1.3-fold (0.11 log units) below the measured one; the range from low to high includes it.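

Replacing pyrimidin-2-yl with pyrimidin-5-yl on the second core lowered the number again in this assay, giving a 2.3-fold lower number from compound 3 to compound 4 (0.36 log units; beyond the scatter), so the change pointed the same way on both cores. The two steps can be set side by side, and the gap between their sizes is no larger than repeat measurements could produce: the same change on two cores in this assay, a 4.5-fold lower number (0.65 log units; beyond the scatter) from compound 1 to compound 2 and a 2.3-fold lower number (0.36 log units; beyond the scatter) from compound 3 to compound 4, 2.0-fold (0.29 log units) apart, within the scatter of two such steps. Among these compounds, this supports carrying the change from one of these cores to the other as a rough guide to direction and size, but with only two pairs it does not show that the step is truly the same on both cores or truly smaller on the second, that it would hold on any further core, or why the swap lowers the number at all.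

The compounds shown compare only these two ring attachments, so they leave open how a pyridin-3-yl or a plain phenyl group would behave in the same place, or a pyrimidine carrying an amine or a carboxylic acid. They also leave open whether the step would survive a longer chain in place of the isopropyl group on the shared core.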